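Ether chain size on the chlorinated ring: compound 4

This account rests on a few compounds, and the source may have more. Where it says the series, first, only, none or still open, it means among the compounds named here.

Measured in a functional assay for inhibition of transient receptor potential cation channel subfamily V member 1 (Homo sapiens), read by fluorescence and calcium flux; on this read-out higher numbers stand for weaker inhibition and lower numbers for stronger inhibition:
compound 1 `COc1cc(-c2cc3c(O)nc(C)nc3cc2C(C)C)ccc1Cl` — 14 nM
compound 2 `COc1cc(Cl)cc(-c2cc3c(O)nc(C)nc3cc2C(C)C)c1` — 100 nM
compound 3 `CCCCOc1cc(-c2cc3c(O)nc(C)nc3cc2C(C)C)ccc1Cl` — 82 nM

Compound 1 gives the lowest of the three numbers in this assay. Its nearest neighbour is compound 3: a 5.9-fold higher number from compound 1 to compound 3 (0.77 log units; beyond the scatter). Compound 2 is not a single-step neighbour of compound 1; the two values simply stand apart, with compound 2 the higher.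

Compound 4 `Cc1nc(O)c2cc(-c3ccc(Cl)c(OC(C)C)c3)c(C(C)C)cc2n1` differs from compound 1 in one place: isopropyl in place of methyl on an oxygen on an aromatic ring. Going by the values given here, the only measured step that bears on it is the lengthening of the same ether in a 5.9-fold higher number from compound 1 to compound 3 (0.77 log units; beyond the scatter), which weakened inhibition modestly. Compound 4 enlarges the ether by fewer atoms than compound 3 does, so a weakening smaller than that step, or at its edge, is expected: a 2.9-fold higher number from compound 1 to compound 4 (0.46 log units; beyond the scatter). For compound 4 the estimate is 40 nM, with a range from 14 nM to 120 nM.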

Compound 4, half-maximal inhibitory concentration: 201 nM
Compound 4: middle estimate off by 5.0-fold (0.70 log units), on the low side; the whole stated range lies below it.
By their numbers in this assay, from the lowest: compound 1; then compounds 3, 2 and 4 (each within the scatter of the next, the first and the last beyond it).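

In this assay, the number at this oxygen on an aromatic ring does not rise with chain carbon count: methoxy to isopropoxy gives a 14-fold higher number from compound 1 to compound 4 (1.16 log units; beyond the scatter), and shortening butyl to the branched isopropyl still gives a 2.5-fold higher number from compound 3 to compound 4 (0.39 log units; beyond the scatter). Among these three ethers, branched isopropyl therefore gives the highest number, although butyl carries more carbons. Nothing available accounts for this order.

Still open, going by these compounds, is whether branching or chain length governs the number here. An ethyl ether, a straight propyl ether and a cyclopropylmethyl ether would help separate the two.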